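This account rests on a few compounds, and the source may have more. Where it says the series, first, only, none or still open, it means among the compounds named here.

Compound 1 `O=C1/C(=C/c2cccc(Cl)c2)Cc2ccccc21`: 41200 nM
Compound 2 `O=C1/C(=C/c2cccc(Br)c2)Cc2ccccc21`: 43300 nM
Compound 3 `Cc1cccc(/C=C2\Cc3ccccc3C2=O)c1`: 50400 nM

All three values come from a functional assay on L1210 cells (Mus musculus) for inhibition; a lower number here means a stronger inhibitor, a higher number a weaker inhibitor. Compound 3 lies within the scatter of both other compounds. The steps leading to it are a 1.2-fold higher number from compound 1 to compound 3 (0.09 log units; within the scatter) and a 1.2-fold higher number from compound 2 to compound 3 (0.07 log units; within the scatter). The remaining step among the three is a 1.1-fold higher number from compound 1 to compound 2 (0.02 log units; within the scatter). For the measured compounds named here, these three small steps are the only guide, and each exchanges one group for another at the same place on the ring.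

The next structure is compound 4 `COc1cccc(/C=C2\Cc3ccccc3C2=O)c1`, which has methoxy in place of methyl on an aromatic carbon, meta to a large group: methoxy in place of methyl on an aromatic carbon. Going by the values given here, no measured step involves methoxy, and its oxygen is new to this small set, so the range must stay fairly wide. Even so, with all three measured steps so small, no step beyond the scatter is expected, and no direction can be favoured. The expected step is a 1.1-fold lower number from compound 3 to compound 4 (0.05 log units; within the scatter). The estimated value for compound 4 is 45000 nM, with an expected range from 25000 nM to 80000 nM.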

Compound 4, half-maximal inhibitory concentration: 217000 nM
Estimate against measurement, compound 4: 4.8-fold (0.68 log units) below; measured number outside the range, above it.
By their numbers in this assay, from the lowest: compounds 1, 2 and 3 (each within the scatter of the next); then compound 4.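

In this assay this place on the ring does not treat every swap alike: chloro, bromo and methyl sit within the scatter of one another, yet methoxy stands apart from methyl (a 4.3-fold higher number from compound 3 to compound 4 (0.63 log units; beyond the scatter)), from bromo (a 5.0-fold higher number from compound 2 to compound 4 (0.70 log units; beyond the scatter)) and from chloro (a 5.3-fold higher number from compound 1 to compound 4 (0.72 log units; beyond the scatter)). For the compounds shown here, the only entering group that carries an oxygen, and with it a hydrogen-bond acceptor, thus gives the weakest inhibitor of the four. Nothing measured here explains this shift.

The compounds shown cannot tell whether the oxygen or the second heavy atom goes with the weaker inhibition, and a hydroxy group or an ethyl group in the same place would separate the two. Going by these compounds, whether methoxy behaves the same way elsewhere on this ring also stays open.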